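The compounds below may be only part of what the source reports. "The series", "measured", "known", "first", "only" and "open" are said of these compounds alone.

Of the compounds shown here, three have been tested in a functional assay on HCT-116 cells (Homo sapiens) for antiproliferative activity, read by CCK-8 assay, with a stated time of 72 h, tested at 2 uM (on this read-out lower numbers stand for a weaker effect and higher numbers for a stronger effect at the one concentration tested), and a fourth awaits its turn. Compound 1, `Cc1ccc(Nc2nc(Cl)nc3c2ncn3Cc2ccc(C(=O)Nc3ccccc3N)cc2)cc1`, gives 76.3% in this assay. Compound 2, `Cc1ccc(Nc2nc(Cl)nc3c2ncn3Cc2ccc(/C=C/C(=O)Nc3ccccc3N)cc2)cc1`, differs from compound 1 in one place only: 2-((2-aminophenyl)carbamoyl)ethenyl in place of (2-aminophenyl)carbamoyl on an aromatic carbon. That single alteration goes with a drop of a number 76 percentage points lower from compound 1 to compound 2 (beyond the scatter), so that compound 2 gives only 0.27% in this assay.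

Compound 3, `CC(C)n1cnc2c(Nc3cccc(Cl)c3)nc(NCOCc3ccc(C(=O)Nc4ccccc4N)cc3)nc21`, is built on a different core; how the two cores differ is not broken down here. In this assay compound 3 gives 7.12%, a number that sits within the usual scatter of the value of compound 2.

Compound 4, `CC(C)n1cnc2c(Nc3cccc(Cl)c3)nc(NCOCc3ccc(/C=C/C(=O)Nc4ccccc4N)cc3)nc21`, stands to compound 3 exactly as compound 2 stands to compound 1: 2-((2-aminophenyl)carbamoyl)ethenyl in place of (2-aminophenyl)carbamoyl on an aromatic carbon. The place of the change is the same in both pairs, so the same change is made on a second core. In the first pair it removed almost all of the effect. A step of the same size cannot repeat here, because compound 3 already gives 7.12% and the read-out cannot fall far below nothing. The change from compound 3 to compound 4 is therefore expected to be small, around a number 5.1 percentage points lower from compound 3 to compound 4 (within the scatter). Whether the second core holds up the effect against this change remains to be seen; on the evidence of the first pair, compound 4 is expected to give about 2%, with a likely range from 0% to 12%.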

Compound 4, a percentage reported as inhibition, at one concentration (the size of the read-out at that concentration, not a potency): 18.5%
Compound 4: middle estimate off by 16.5 percentage points, on the low side; the measured number lies above the stated range.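

In this assay, the same swap of (2-aminophenyl)carbamoyl for 2-((2-aminophenyl)carbamoyl)ethenyl does not give the same result on the two cores: the same change on two cores in this assay, a number 76 percentage points lower (beyond the scatter) from compound 1 to compound 2 and a number 11.4 percentage points higher (beyond the scatter) from compound 3 to compound 4, 87.4 percentage points apart, beyond the scatter of two such steps

On the second core the step is a number 11.4 percentage points higher from compound 3 to compound 4 (beyond the scatter), so the near-total loss seen on the core of compound 1 did not carry over to the core of compound 3, and the outcome of this change on one core did not predict its outcome on the other. This does not show which part of the cores decides the outcome, since they differ in several places at once, and two pairs are too few to support a general rule for the series.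

The compounds shown leave open how other links on the same aromatic ring would behave on each core, such as a saturated ethyl chain in place of the ethenyl or a longer chain. They also leave open whether a hydroxamic acid in place of the 2-aminophenyl amide would show the same dependence on the core, and each result here is a reading at one concentration rather than a measure of potency.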